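The compounds below may be only part of what the source reports. "The series", "measured", "known", "first", "only" and "open" are said of these compounds alone.

Two compounds in the series carry measurements in a functional assay on MCF7 cells (Homo sapiens) for antiproliferative activity, read by MTT assay, with stated times of 24 h and 72 h; a lower number here means a stronger inhibitor, a higher number a weaker inhibitor. Compound 1 `COc1ccc([C@@H]2[C@@H](Oc3ccccc3)C(=O)N2c2cc(OC)c(OC)c(OC)c2)cc1` gives 6900 nM in this assay. Compound 2 `COc1cc(N2C(=O)[C@@H](Oc3ccccc3)[C@H]2c2ccc3ccccc3c2)cc(OC)c1OC` gives 282000 nM in this assay, the higher of the two numbers and far beyond the scatter from compound 1. Compound 3 `COc1cc(N2C(=O)[C@@H](Oc3ccccc3)[C@H]2c2cc(O)c(OC)c([N+](=O)[O-])c2)cc(OC)c1OC` is not yet measured. It differs from compound 2 in one place: a group of 12 heavy atoms (7 carbon, 1 nitrogen, 4 oxygen; one six-membered aromatic ring of carbon only) in place of a group of 10 heavy atoms (10 carbon; 2 six-membered aromatic rings of carbon only), on a saturated ring carbon. Within the data shown here, with only two measured compounds and no single-change step between them, direction must rest on the gap between compound 1 and compound 2. The step of a 19-fold lower number from compound 2 to compound 3 (1.27 log units; beyond the scatter) is expected to be a fall beyond the scatter. For compound 3 the estimate in this assay is 15000 nM, with a range from 3000 nM to 80000 nM.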

Compound 3, half-maximal inhibitory concentration: 69000 nM
Estimate against measurement, compound 3: 4.6-fold (0.66 log units) below; low and high end bracket the measured number.
By their numbers in this assay, from the lowest: compound 1; then compound 3; then compound 2.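

On the saturated ring carbon of the four-membered ring, the single substituted aromatic ring in place of naphthalen-2-yl gives a 4.1-fold lower number from compound 2 to compound 3 (0.61 log units; beyond the scatter) in this assay as a modest gain. The position therefore accepts a change from two aromatic rings to one, together with added hydrogen-bond donor and acceptors. No measured evidence explains this step. 

The hydroxy, methoxy and nitro groups change together, so their separate contributions remain unresolved. Also open, from the compounds shown here alone, is how a smaller aryl group carrying an amine or a carboxylic acid would compare at this ring carbon.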